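From compound 3 to compound 4: same atoms, rejoined

A few compounds are considered here, and "the series" means these few. Any claim that something is new, unique, unknown or untested is made for them only; others in the source may bear on it.

Measured so far in a functional assay on MCF7 cells (Homo sapiens) for inhibition, read by fluorescence, with a stated time of 72 h (on this read-out lower numbers stand for stronger inhibition and higher numbers for weaker inhibition), and still far from strong inhibition:
compound 1 `CC(C)n1cnc2c(NC(=N)N)nc(N)nc21` gives 97200 nM here
compound 2 `CC[C@@H](N)COc1nc(NC(=N)N)c2ncn(C(C)C)c2n1` gives > 100000 nM here
compound 3 `CC(C)[C@@H](N)COc1nc(NC(=N)N)c2ncn(C(C)C)c2n1` gives 79400 nM here

For compound 2 the entry > 100000 nM is a limit and not a number. Among the compounds with values here, compound 1 and compound 3 hold the only two true numbers, and these lie within the scatter of each other. Replacing the amino group gave an at least 1.0-fold higher number from compound 1 to compound 2 (0.01 log units; that floor lies within the scatter) in one case and a 1.2-fold lower number from compound 1 to compound 3 (0.09 log units; within the scatter) in the other, while adding a methyl gave an at least 1.2-fold lower number from compound 2 to compound 3 (0.10 log units; that floor lies within the scatter) as its result. None of these steps goes beyond the scatter.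

Compound 4 `CC(C)[C@H](CO)Nc1nc(NC(=N)N)c2ncn(C(C)C)c2n1` carries the same atoms joined differently, with (1-(hydroxymethyl)-2-methylpropyl)amino in place of 2-amino-3-methylbutoxy on an aromatic carbon is the change. Within the data shown here, no measured step tests this exchange directly. Judging from the flat a 1.2-fold lower number from compound 1 to compound 3 (0.09 log units; within the scatter) seen for compound 3, no step beyond the scatter is expected in this assay here. The estimated move is a 1.6-fold lower number from compound 3 to compound 4 (0.20 log units; within the scatter) and no more. For compound 4 the expected value is 50000 nM, with an estimated range from 12000 nM to 120000 nM as its span.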

Compound 4, half-maximal inhibitory concentration: 10500 nM
Beside the measured number, compound 4's estimate is 4.8-fold (0.68 log units) above it; the measured number lies below the stated range.
By their numbers in this assay, from the lowest: compound 4; then compounds 3 and 1 (each within the scatter of the next). At a limit, above all of these: compound 2.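

Until now no change at this position, the aromatic carbon between two ring nitrogen atoms, had moved the number beyond the scatter, yet replacing 2-amino-3-methylbutoxy with (1-(hydroxymethyl)-2-methylpropyl)amino, built from the same atoms, gives a 7.6-fold lower number from compound 3 to compound 4 (0.88 log units; beyond the scatter) in this assay. The same group, compared with the plain amino group, gives a 9.3-fold lower number from compound 1 to compound 4 (0.97 log units; beyond the scatter), and compared with 2-aminobutoxy it gives an at least 9.5-fold lower number from compound 2 to compound 4 (0.97 log units; beyond the scatter). That last step is only a floor, and compound 2 carries a limit and not a number: the limit of > 100000 nM in this assay, at which 1 of the 4 values shown sits.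

Even so, compound 4 at 10500 nM remains far from strong inhibition. The linking atom and the end of the chain change together in this exchange, so the compounds shown do not separate their contributions, and a simple isobutylamino group, without the hydroxyl, would be the plainest comparison.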